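The source may report more compounds than this note shows. Statements on the series, on what has been measured and on what is new or still open speak of the compounds shown alone.

Compound 1 `O=C(NCCC1CC1)c1ccc(N2CCC(Oc3ccccc3C(F)(F)F)CC2)nn1` gives 14 nM in an assay on microsomes from liver for inhibition of acyl-CoA desaturase 1 (Rattus norvegicus) (on this read-out lower numbers stand for stronger inhibition and higher numbers for weaker inhibition), the lowest of the three numbers measured. Compound 3 `CC(=O)c1ccccc1OC1CCN(c2ccc(-n3ccnc3)nn2)CC1` gives 34 nM in this assay, and compound 2 `Cc1cccc(OC2CCN(c3ccc(-n4ccnc4)nn3)CC2)c1` gives 251 nM. Going by the values given here, the only measured step, a 7.4-fold lower number from compound 2 to compound 3 (0.87 log units; beyond the scatter), changes the ring on the oxygen, a part of the shared core that compound 4 `CC(C)(C)c1nnc(-c2ccc(N3CCC(Oc4ccccc4C(F)(F)F)CC3)nn2)o1` keeps unchanged. Compound 4 differs from compound 1 by 5-(tert-butyl)-1,3,4-oxadiazol-2-yl in place of (2-cyclopropylethyl)carbamoyl on an aromatic carbon. Among the compounds with values here, no measured step touches this position, so the expectation rests on compound 1 alone, and the change is expected to stay within or near the scatter. Compound 4 is therefore expected to give 20 nM in this assay, between 5 nM and 80 nM, meaning an expected step of a 1.4-fold higher number from compound 1 to compound 4 (0.15 log units; within the scatter).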

Compound 4, half-maximal inhibitory concentration: 980 nM
For compound 4 the middle estimate is 49-fold (1.69 log units) below the measured one; the whole stated range lies below it.
By their numbers in this assay, from the lowest: compound 1; then compound 3; then compound 2; then compound 4.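

In this assay, swapping (2-cyclopropylethyl)carbamoyl for 5-(tert-butyl)-1,3,4-oxadiazol-2-yl gives a 70-fold higher number from compound 1 to compound 4 (1.85 log units; beyond the scatter), so this position is far from indifferent to the group it carries. The entering group has no hydrogen-bond donor and the leaving group has one, but this is only one of several differences between them. No available measurement explains the loss.

From the compounds shown here alone, it remains open whether the oxadiazole ring or its tert-butyl group accounts for the change. A methyl in place of the tert-butyl, or a carboxylic acid in place of the whole group, could help separate these possibilities.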